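The source may hold more compounds than are shown below. What is called first, only, known or untested is meant among the compounds shown, and "the series" means these compounds.

Compound 1 `Cc1nc(-c2cc(C(F)(F)F)ccc2[C@H]2CCOc3cc(S(=O)(=O)Nc4ccncn4)ccc32)co1` carries a 2-methyl-1,3-oxazol-4-yl group on the aromatic carbon described below and a sulfonamide linked to a pyrimidine. In a physicochemical assay for lipophilicity (a higher number here means a more lipophilic compound, a lower number a more polar compound), compound 1 gives "not determined" (no result reported), so compound 1 stands with no number of its own in this assay. Two relatives of the same series do have numbers. Compound 2 `O=S(=O)(Nc1nccs1)c1ccc2c(c1)OCC[C@H]2c1ccc(C(F)(F)F)cc1-c1nccs1` gives 3.3 in this assay. Compound 3 `Cc1nc(-c2cc(C(F)(F)F)ccc2[C@H]2CCOc3cc(S(=O)(=O)Nc4ncc(F)cn4)ccc32)co1` shares the oxazole of compound 1 and differs from it only in the sulfonamide partner. In this assay compound 3 gives 2.8. These two values give the neighbourhood in which compound 1 and its close analogues appear to sit.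

Compound 4 `Cn1nccc1-c1cc(C(F)(F)F)ccc1[C@H]1CCOc2cc(S(=O)(=O)Nc3ccncn3)ccc21` is the next compound awaiting measurement. The change from compound 1 to compound 4 is 1-methyl-1H-pyrazol-5-yl in place of 2-methyl-1,3-oxazol-4-yl on an aromatic carbon. Within the data shown here, compound 1 itself has no number, and no step for this exchange can be computed. One five-membered aromatic ring with two hetero atoms is swapped for another of the same size and count, so the reader may expect a step in this assay that is small, likely no larger than the usual scatter, with at most a slight lean toward the lower side. On that basis, compound 4 is estimated to give 2.5 in this assay, with an expected range from 1.9 to 3.1.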

Compound 4, distribution coefficient: 1.8
Compound 4: the middle estimate sits 0.70 log units above what was measured; the whole stated range lies above it.
By their numbers in this assay, from the lowest: compound 4; then compound 3; then compound 2.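

No new step can be read for compound 4 in this assay: compound 1 has no number to set against it, and compounds 2 and 3 differ from it in more than one place. The compounds shown leave open what the exchange of 2-methyl-1,3-oxazol-4-yl for 1-methyl-1H-pyrazol-5-yl does on its own. Nothing shown offers an explanation for the value of compound 4.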